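Pyrazole chalcones: removing one methoxy on either aryl ring

The compounds below may be only part of what the source reports. "The series", "measured", "known", "first", "only" and "open" are said of these compounds alone.

Compound 1 `COc1cc(-c2cc(/C=C/C(=O)c3ccc(N)cc3)[nH]n2)cc(OC)c1OC` and compound 4 `COc1ccc(-c2cc(/C=C/C(=O)c3ccc(N)cc3)[nH]n2)cc1OC` share a core that differs from that of compound 2 `COc1ccc(C(=O)/C=C/c2cc(-c3cc(OC)c(OC)c(OC)c3)n[nH]2)cc1OC` and compound 3 `COc1ccc(C(=O)/C=C/c2cc(-c3cc(OC)c(OC)c(OC)c3)n[nH]2)cc1` by 4-aminophenyl in place of 3,4-dimethoxyphenyl on a carbonyl carbon. In a functional assay on KM12 cells (Homo sapiens) for cytotoxicity, read by sulforhodamine B assay, with a stated time of 48 h, tested at 10 uM (on this read-out lower numbers stand for a stronger effect and higher numbers for a weaker effect at the one concentration tested), compound 1 gives -67%, compound 2 gives -87% and compound 3 gives -88%. The steps of a number 20 percentage points lower from compound 1 to compound 2 (beyond the scatter) and a number 21 percentage points lower from compound 1 to compound 3 (beyond the scatter) both lie beyond the scatter. From compound 2 to compound 3 the change is hydrogen in place of methoxy on an aromatic carbon, and it made a number 1 percentage points lower from compound 2 to compound 3 (within the scatter). From compound 1 to compound 4 the change is hydrogen in place of methoxy on an aromatic carbon, where the place is also meta to a methoxy group, so this is the same kind of change, not the same. Resting on a number 1 percentage points lower from compound 2 to compound 3 (within the scatter) alone, the expected step is a number 5 percentage points higher from compound 1 to compound 4 (within the scatter), with widened uncertainty for the different surroundings. Compound 4 is therefore estimated at -62%, likely between -85% and -30%.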

Compound 4, a percentage reported as activity, at one concentration (the size of the read-out at that concentration, not a potency): -79%
Beside the measured number, compound 4's estimate is 17 percentage points above it, within the range that was stated.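

In this assay, going by these compounds alone, hydrogen in place of methoxy on an aromatic carbon gives a number 12 percentage points lower from compound 1 to compound 4 (beyond the scatter), and the two cores do not differ measurably in their response to this kind of change: the same change on two cores in this assay, a number 1 percentage points lower (within the scatter) from compound 2 to compound 3 and a number 12 percentage points lower (beyond the scatter) from compound 1 to compound 4, 11 percentage points apart, within the scatter of two such steps Across these two pairs, the change therefore carries from one core to the other without a detectable difference, although only the step on the core of compound 1 lies beyond the scatter. This does not establish a general rule, since the change sits in different surroundings in the two pairs and each number comes from one concentration, not from a potency measurement.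

The compounds shown leave open how hydroxy, fluoro or ethoxy at the same place would compare with methoxy or hydrogen. They also leave open whether the step holds on any further core.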